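This account rests on a few compounds, and the source may have more. Where it says the series, first, only, none or still open, it means among the compounds named here.

Measured compounds:
compound 1 `CN1CCN(CC(=O)Nc2ccc(-c3nc4cc(Cl)c(Cl)cc4[nH]3)cc2)CC1`: in an ADME assay on MT4 cells (Homo sapiens) for cytotoxicity, read by MTT assay, with a stated time of 96 h (on this read-out lower numbers stand for higher toxicity in this test and higher numbers for lower toxicity in this test), compound 1 gives 11000 nM.
compound 2 `CCC(=O)Nc1ccc(-c2nc3cc(C(F)(F)F)ccc3[nH]2)cc1`: in this assay compound 2 reaches only the limit >= 100000 nM, which is a limit of the test and not a number.

Within the data shown here, of the two values shown, compound 1 holds the only number; the other value is a limit, as the limit of >= 100000 nM in this assay, at which 1 of the 2 values shown sits, records. Compound 3 `O=C(CN1CCCCC1)Nc1ccc(-c2nc3cc(Cl)c(Cl)cc3[nH]2)cc1` differs from compound 1 by piperidin-1-yl in place of 4-methylpiperazin-1-yl on a saturated chain carbon bound to a carbonyl carbon. Among the measured compounds shown here, no measured step covers this change, so only a small step is expected, within the scatter, in either direction. Compound 3 is therefore estimated at 10000 nM in this assay, with a range from 4000 nM to 30000 nM. That amounts to an expected step of a 1.1-fold lower number from compound 1 to compound 3 (0.04 log units; within the scatter).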

Compound 3, half-maximal cytotoxic concentration: 54000 nM
For compound 3 the middle estimate is 5.4-fold (0.73 log units) below the measured one, and the stated range ends below it.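

At this place, on a saturated chain carbon bound to a carbonyl carbon, the choice of ring clearly changes the read-out: piperidin-1-yl in place of 4-methylpiperazin-1-yl gives a 4.9-fold higher number from compound 1 to compound 3 (0.69 log units; beyond the scatter) in this assay, which means lower toxicity in this test. Nothing measured here explains this step. This is one pair on one core, so it shows no general rule. Still open, going by these compounds, is whether the same change would hold on another core, and how a piperazin-1-yl without the methyl, a morpholin-4-yl or an open-chain dimethylamino group would read at this place.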